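This account rests on a few compounds, and the source may have more. Where it says the series, first, only, none or still open, it means among the compounds named here.

Measured compounds:
- compound 1, `CCC(NC(=O)C(CC(C)C)NC(=O)OCc1ccccc1)C(=O)C(=O)NCC1(C)CC(O)CC(C)(C)C1`: 420 nM
- compound 2, `CCC(NC(=O)C(CC(C)C)NC(=O)OCc1ccccc1)C(=O)C(=O)NCCCN1CCCc2ccccc21`: 370 nM

In an assay on isolated protein for inhibition of Calpain-1 catalytic subunit (Homo sapiens) (on this read-out lower numbers stand for stronger inhibition and higher numbers for weaker inhibition), compound 1 gives 420 nM and compound 2 gives 370 nM. Compound 2 has the lower of the two numbers, yet its gap to compound 1 is within the scatter, so the two cannot be ordered. For the measured compounds named here, the only measured step, a 1.1-fold lower number from compound 1 to compound 2 (0.06 log units; within the scatter), exchanged the whole terminal group on the saturated chain carbon bound to the amide-type nitrogen and produced no change beyond the scatter.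

Compound 3, `CCC(NC(=O)C(CC(C)C)NC(=O)OCc1ccccc1)C(=O)C(=O)NCCCN1CCc2ccccc2C1`, is not yet measured. It differs from compound 2 by 1,2,3,4-tetrahydroisoquinolin-2-yl in place of 1,2,3,4-tetrahydroquinolin-1-yl on a saturated chain carbon, three bonds along the chain from an amide-type nitrogen. Going by the values given here, no measured step touches this exact change; the step from compound 1 to compound 2 is the nearest point of reference, and it shows that a larger exchange in the same region left this assay unmoved. He therefore expects no step beyond the scatter, no change at the digits printed from compound 2 to compound 3 (within the scatter), for compound 3. His estimate for compound 3 in this assay is 370 nM, with a range from 150 nM to 900 nM.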

Compound 3, inhibition constant: 310 nM
Estimate against measurement, compound 3: 1.2-fold (0.08 log units) above; the measured number falls inside the stated range.
By their numbers in this assay, from the lowest: compounds 3, 2 and 1 (each within the scatter of the next).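

Exchanging 1,2,3,4-tetrahydroquinolin-1-yl for 1,2,3,4-tetrahydroisoquinolin-2-yl on a saturated chain carbon, three bonds along the chain from an amide-type nitrogen, gives a 1.2-fold lower number from compound 2 to compound 3 (0.08 log units; within the scatter), so in this assay joining the same atoms differently within the terminal group does not separate the two compounds. The earlier pair had covered only an exchange of the whole terminal group, whereas this pair keeps the atom count and ring types unchanged and alters only how the atoms are connected. The wider exchange, read again with the new member, gives a 1.4-fold lower number from compound 1 to compound 3 (0.13 log units; within the scatter), so the position has still shown no step beyond the scatter among the three terminal groups at hand.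

No supporting evidence bears on why these numbers stay so close, and the data offer no explanation of it. Whether this position can move the read-out at all remains open, as the compounds shown do not include a terminal morpholine, a terminal carboxylic acid or a longer chain leading to the 1,2,3,4-tetrahydroisoquinolin-2-yl group, any of which would test it further.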